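The source may report more compounds than this note shows. Statements on the series, on what has been measured and on what is new or still open speak of the compounds shown alone.

Two compounds open the series. Compound 1 `CN1CCN(c2ccc3[nH]nc(S(=O)(=O)c4c(Cl)cccc4Cl)c3c2)CC1` reaches 100% in a functional assay on HeLa cells for antagonist activity at 5-hydroxytryptamine receptor 6 (Homo sapiens); a lower number here means a smaller maximal response, a higher number a larger maximal response. Compound 2 `COc1ccc(S(=O)(=O)c2n[nH]c3ccc(N4CCN(C)CC4)cc23)cc1`, which carries a 4-methoxyphenyl in place of the 2,6-dichlorophenyl on the sulfonyl sulfur, reaches 100% in this assay. The step of no change at the digits printed from compound 1 to compound 2 (within the scatter) shows that swapping the aryl on the sulfonyl sulfur left the largest response untouched, so compound 2 stands level with compound 1 at the digits shown, and neither can be called stronger than the other.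

Compound 3 `CN1CCN(c2ccc3[nH]nc(S(=O)(=O)c4ccc(Cl)cc4)c3c2)CC1` is the next member. Its difference from compound 2 is chloro in place of methoxy on an aromatic carbon. Within the data shown here, the only step that bears on this change is the one from compound 1 to compound 2, in which a different group on the same aryl was exchanged and no change at the digits printed from compound 1 to compound 2 (within the scatter) resulted. With both measured compounds sitting at the full response, the expectation for compound 3 is a step of no change at the digits printed from compound 2 to compound 3 (within the scatter), that is, nothing beyond the scatter. Compound 3 is therefore estimated to reach 100% in this assay, with a range from 85% to 110%.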

Compound 3, largest response reached (reported as Imax), in percent of the reference or control that the assay uses: 100%
The estimate for compound 3 equals the measured number at the digits printed; the range from low to high includes it.
By their numbers in this assay, from the lowest: compounds 1, 2 and 3 (each within the scatter of the next).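

Compound 2 and compound 3 differ only at the aromatic carbon para to a large group, where 4-methoxyphenyl becomes 4-chlorophenyl, and in this assay this exchange gives no change at the digits printed from compound 2 to compound 3 (within the scatter). Unlike the earlier step, which replaced the whole substitution pattern of the aryl, this one changes a single substituent: methoxy, with 2 heavy atoms and 1 hydrogen-bond acceptor, gives way to chloro, with 1 heavy atom and no acceptor, and the largest response stays level. The move from 2,6-dichlorophenyl to 4-chlorophenyl on the sulfonyl sulfur gives no change at the digits printed from compound 1 to compound 3 (within the scatter), and no measurement is at hand that could account for this flat picture.

All three compounds stand level, so these data do not show whether any group at this carbon can separate one compound from another in this assay. An amine or a carboxylic acid in place of chloro, or a longer chain such as butoxy in place of methoxy, remains an open case, as does any change to the shared core away from the aryl.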